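Hydroxyphenyl rearrangement on a shared pyridine-centred core

The source may report more compounds than this note shows. Statements on the series, on what has been measured and on what is new or still open speak of the compounds shown alone.

A small set of three-armed aromatic compounds was examined in an assay on isolated protein for inhibition of DNA topoisomerase 1 (Homo sapiens), with a stated time of 30 min, tested at 20 uM; a higher number here means a stronger effect of the compound at the concentration tested, a lower number a weaker effect. Compound 1 `Oc1ccc(-c2cc(-c3cccs3)cc(-c3ccccc3O)n2)cc1` gives 2% in this assay. Compound 2 `Oc1ccc(-c2cc(-c3cccs3)cc(-c3cccc(O)c3)n2)cc1` differs from it by 3-hydroxyphenyl in place of 2-hydroxyphenyl on an aromatic carbon, and compound 2 gives 1.1%. The step of a number 0.9 percentage points lower from compound 1 to compound 2 (within the scatter) therefore leaves the read-out where it was.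

Compound 3 `Oc1ccccc1-c1cc(-c2ccccn2)cc(-c2ccccc2O)n1` belongs to the same series, but in this assay compound 3 gives "not determined" (no result reported), so no single number is available for it; how the core of compound 3 differs from the core of compound 1 is not broken down here. Compound 4 `Oc1cccc(-c2cc(-c3ccccn3)cc(-c3ccccc3O)n2)c1` is the not yet measured partner of compound 3, and the change from compound 3 to compound 4 is 3-hydroxyphenyl in place of 2-hydroxyphenyl on an aromatic carbon. Going by the values given here, it is the same kind of change as the one from compound 1 to compound 2, though the surroundings of the place differ: in compound 1 the exchanged group sits meta to a 4-hydroxyphenyl group and meta to a thiophen-2-yl group, whereas in compound 3 it sits meta to a 2-hydroxyphenyl group and meta to a pyridin-2-yl group.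

Because the step of a number 0.9 percentage points lower from compound 1 to compound 2 (within the scatter) stayed within the scatter, the same kind of change is expected to move compound 4 little from wherever compound 3 would stand, and with compound 3 itself unmeasured only the low level seen for compound 1 and compound 2 remains as a guide. Compound 4 is therefore estimated at 3% in this assay, expected to lie between 0% and 15%.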

Compound 4, a percentage reported as inhibition, at one concentration (the size of the read-out at that concentration, not a potency): 0.1%
Compound 4: middle estimate off by 2.9 percentage points, on the high side; the range from low to high includes it.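

In this assay, going by these compounds alone, compound 3 gives "not determined" (no result reported) and compound 4 gives 0.1%, so no step between these two compounds can be read. The compounds shown leave open whether 3-hydroxyphenyl in place of 2-hydroxyphenyl changes the read-out in these surroundings as little as it does between compound 1 and compound 2. Nothing in the data shown bears on the cause of the value of compound 4.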